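The compounds below may be only part of what the source reports. "The series", "measured", "known", "first", "only" and "open" are said of these compounds alone.

In a functional assay on HCT-116 cells (Homo sapiens) for antiproliferative activity, read by MTT assay, with a stated time of 72 h (on this read-out lower numbers stand for stronger inhibition and higher numbers for weaker inhibition), compound 1 (`COc1cc(CCc2ccc(F)cc2)cc(OC)c1O`) gives 1190 nM and compound 2 (`COc1cc(CCc2ccc(Br)cc2)cc(OC)c1O`) gives 15900 nM, the higher of the two numbers and so the weaker inhibition. Compound 3 (`COc1cc(CCc2ccc([N+](=O)[O-])cc2)cc(OC)c1O`) carries nitro in place of bromo on an aromatic carbon, para to a large group (nitro in place of bromo on an aromatic carbon). Among the compounds with values here, one measured step bears on this: exchanging the group at that place gave a 13-fold higher number from compound 1 to compound 2 (1.13 log units; beyond the scatter) and that step is large. One step cannot settle the direction, but a moderate fall from that high number is expected (a 3.2-fold lower number from compound 2 to compound 3 (0.50 log units; beyond the scatter)). For compound 3 the expected value is 5000 nM (estimated range 1000 nM to 20000 nM).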

Compound 3, half-maximal inhibitory concentration: 3160 nM
Beside the measured number, compound 3's estimate is 1.6-fold (0.20 log units) above it; low and high end bracket the measured number.
By their numbers in this assay, from the lowest: compound 1; then compound 3; then compound 2.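

The third group shows that the loss seen with bromo at this place is not fixed: a 5.0-fold lower number from compound 2 to compound 3 (0.70 log units; beyond the scatter) recovers part of it, while a 2.7-fold higher number from compound 1 to compound 3 (0.42 log units; beyond the scatter) leaves nitro short of fluoro. From the lowest number, the order is fluoro, nitro, bromo. Nitro has 3 heavy atoms against 1 for bromo, yet gives the lower number, so more heavy atoms here did not mean weaker inhibition, and nothing available explains this order. From the compounds shown here alone, whether chloro would fall between fluoro and bromo remains open. So does where an amine at this place would stand.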